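The source may report more compounds than this note shows. Statements on the series, on what has been measured and on what is new or still open speak of the compounds shown alone.

In a functional assay on M21 cells (Homo sapiens) for antiproliferative activity, read by sulforhodamine B assay, with a stated time of 48 h (on this read-out lower numbers stand for stronger inhibition and higher numbers for weaker inhibition), compound 1 (`CCCCN1CCN(c2ccc(S(=O)(=O)Oc3cccc(Br)c3)cc2)C1=O`) gives 35000 nM. Compound 2 (`CCCCN1CCN(c2ccc(S(=O)(=O)Oc3cc(F)cc(F)c3)cc2)C1=O`) gives > 100000 nM, which is a limit of the assay and not a number, so compound 2 has no exact position on this scale. Compound 3 (`CCCCN1CCN(c2ccc(S(=O)(=O)Oc3ccc(OC)cc3)cc2)C1=O`) has 4-methoxyphenyl in place of 3,5-difluorophenyl on an oxygen. Going by the values given here, only one measured step bears on this change: an at least 2.8-fold higher number from compound 1 to compound 2 (0.45 log units; beyond the scatter), which swaps the group on the same oxygen and lies beyond the scatter. It shows that this group can shift the read-out, but its size is open-ended. Among the compounds with values here, with compound 1 at 35000 nM as the only exact value, a modest move towards a lower number is expected. The estimated step is an at least 2.8-fold lower number from compound 2 to compound 3 (0.45 log units; beyond the scatter). Compound 3 is expected at 35000 nM, with an estimated range from 9000 nM to 100000 nM.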

Compound 3, half-maximal inhibitory concentration: > 100000 nM
Compound 3 gave a limit, no number; the forecaster's own chance of this, stated with the estimate: 35%; middle value at least 2.8-fold (0.45 log units) away from the limit.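

In this assay, the change from 3-bromophenyl to 4-methoxyphenyl on the oxygen gives an at least 2.8-fold higher number from compound 1 to compound 3 (0.45 log units; beyond the scatter). A second, different group on this oxygen therefore also gives a weaker read-out than 3-bromophenyl, so compound 1 remains the only one of the three with an exact value. The step from compound 2 to compound 3 cannot be read, and 3,5-difluorophenyl and 4-methoxyphenyl cannot be ranked against each other: the limit of > 100000 nM in this assay, at which 2 of the 3 values shown sit.

The compounds shown leave open whether the bromine itself or its place on the ring sets compound 1 apart, which a 4-bromophenyl or a 3-chlorophenyl group on the same oxygen would test. They also leave open whether a 3-methoxyphenyl group here would bring the read-out back to an exact value.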